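Carbamoyl in Place of Methylphenyl on the Shared Core

The source may report more compounds than this note shows. Statements on the series, on what has been measured and on what is new or still open speak of the compounds shown alone.

Compound 1 `COc1ccc(-n2c(SCc3ccc(C)cc3)nnc2-c2cc(OC)c(OC)c(OC)c2)cc1` gives 31600 nM in a functional assay on HepG2 cells (Homo sapiens) for inhibition, read by MTT assay, with a stated time of 48 h; on this read-out lower numbers stand for stronger inhibition and higher numbers for weaker inhibition.
Compound 2 `COc1ccc(NC(=O)CSc2nnc(-c3cc(OC)c(OC)c(OC)c3)n2-c2ccc(OC)cc2)cc1` reaches only the limit > 60000 nM in this assay.
Compound 3 `COc1cc(-c2nnc(SCc3ccc(C)cc3)n2-c2ccc(N(C)C)cc2)cc(OC)c1OC` likewise reaches only the limit > 60000 nM in this assay.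

Compound 3 therefore stands at the limit of > 60000 nM in this assay, at which 2 of the 3 values shown sit, with no number of its own. Compound 4 `COc1cc(-c2nnc(SCC(=O)Nc3ccc(Cl)cc3)n2-c2ccc(N(C)C)cc2)cc(OC)c1OC` differs from it as follows: (4-chlorophenyl)carbamoyl in place of 4-methylphenyl on a saturated chain carbon bound to a sulfur. For the measured compounds named here, the one measured step of the same kind, an at least 1.8-fold higher number from compound 1 to compound 2 (0.27 log units; that floor lies within the scatter), ran from a measured number to the limit, and compound 3 already sits at that limit, so no step beyond the scatter in a useful direction is expected for this assay. Compound 4 is expected to remain at or beyond the limit, estimated at 70000 nM between 30000 nM and 150000 nM, a step that the limit leaves unreadable from compound 3 to compound 4.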

Compound 4, half-maximal inhibitory concentration: > 60000 nM
Compound 4: no number, only a limit; the forecaster's own chance of this, stated with the estimate: 70%; the middle value is on the limit's open side.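

In this assay compound 4 reaches only the limit > 60000 nM. For the compounds shown here, compound 3 also stands at a limit, so no step between these two compounds can be read. The compounds shown leave open whether (4-chlorophenyl)carbamoyl in place of 4-methylphenyl changes inhibition at all.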